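The source may hold more compounds than are shown below. What is called first, only, known or untested is meant among the compounds shown, and "the series" means these compounds.

Measured compounds in a functional assay on DU-145 cells (Homo sapiens) for inhibition, read by trypan blue exclusion, with a stated time of 96 h; on this read-out lower numbers stand for stronger inhibition of growth and higher numbers for weaker inhibition of growth

- compound 1 `Cc1ccc(S/C(=C/c2c[nH]c3ccccc23)C(=O)c2ccc(Br)cc2)cc1` gives 10000 nM
- compound 2 `COc1ccc(C(=O)/C(=C\c2ccc(OC)c(O)c2)Sc2ccc(F)cc2)cc1` gives 1000 nM

Compound 1 has the higher of the two numbers, and the gap to compound 2 lies beyond the scatter. Among the compounds with values here, no step between measured compounds differing in one place is available, so the size of any single change is unknown.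

Compound 3 `COc1ccccc1/C=C(/Sc1ccc(C)cc1)C(=O)c1ccc(Br)cc1` is still unmeasured. It departs from compound 1 as follows: 2-methoxyphenyl in place of 1H-indol-3-yl on a double-bonded chain carbon bound to a double-bonded chain carbon and the core is otherwise kept.

In this assay a moderate step to a lower number is expected, though one within the scatter remains possible. Within the data shown here, the only guide is compound 2 at 1000 nM as a second compound without the 1H-indol-3-yl group. The estimated change is a 3.3-fold lower number from compound 1 to compound 3 (0.52 log units; beyond the scatter) and it remains an expectation. For compound 3 the estimated value is 3000 nM with an expected range from 800 nM to 10000 nM in this read-out.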

Compound 3, concentration for 50% growth inhibition: 9000 nM
Compound 3: the middle estimate sits 3.0-fold (0.48 log units) below what was measured; the range from low to high includes it.
By their numbers in this assay, from the lowest: compound 2; then compounds 3 and 1 (each within the scatter of the next).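

In this assay, within the data shown here, 2-methoxyphenyl in place of 1H-indol-3-yl, on a double-bonded chain carbon bound to a double-bonded chain carbon, gives a 1.1-fold lower number from compound 1 to compound 3 (0.05 log units; within the scatter) and this is the first single-place step. The change removes the five-membered aromatic ring and the hydrogen-bond donor and adds a hydrogen-bond acceptor, yet the step stays within the scatter, so this pair does not separate the two groups. No measurement at hand explains this outcome.

On these data alone, whether a carboxylic acid or an amine at this place would move the number beyond the scatter remains open. Also open, as far as these compounds go, is whether the same exchange gives a step of similar size on a core other than that of compound 1.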